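This account rests on a few compounds, and the source may have more. Where it says the series, first, only, none or still open, it means among the compounds named here.

Values in a functional assay on U-373MG ATCC cells for inhibition, with U373 MG (Homo sapiens) as the target, read by MTT assay, with a stated time of 7 days; on this read-out lower numbers stand for stronger inhibition of growth and higher numbers for weaker inhibition of growth

Compound 1 `C#CCn1nnc2c(C(N)=O)ncn2c1=O` gives 37600 nM
Compound 2 `C[Si](C)(C)CCOCn1nnc2c(C(N)=O)ncn2c1=O` gives 25300 nM
Compound 3 `NC(=O)c1ncn2c(=O)n(Cc3ccccc3)nnc12` gives > 50000 nM

Compound 3 has no number, only a limit of the assay (the limit of > 50000 nM in this assay, at which 1 of the 3 values shown sits). Compound 4 `NC(=O)c1ncn2c(=O)n(Cc3ccco3)nnc12` carries furan-2-yl in place of phenyl on a saturated chain carbon bound to an aromatic nitrogen. Three measured steps at that same place bear on it, a 1.5-fold lower number from compound 1 to compound 2 (0.17 log units; within the scatter) and an at least 1.3-fold higher number from compound 1 to compound 3 (0.12 log units; that floor lies within the scatter) and an at least 1.9-fold higher number from compound 2 to compound 3 (0.29 log units; that floor lies within the scatter) and each of them lies within the scatter. No step beyond the scatter is therefore expected in this assay for this change. The estimated step is an at least 1.2-fold lower number from compound 3 to compound 4 (0.09 log units; that floor lies within the scatter) and it is expected to stay within the scatter. For compound 4 the expected value is 40000 nM with an estimated range from 18000 nM to 50000 nM and a limit of the assay is also expected as a possible outcome.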

Compound 4, concentration for 50% growth inhibition: > 50000 nM
Compound 4: no number, only a limit; the forecaster's own chance of this, stated with the estimate: 35%; middle value at least 1.2-fold (0.09 log units) away from the limit.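

In this assay, furan-2-yl in place of phenyl leaves compound 4 with a limit, not a number, as for compound 3: the limit of > 50000 nM in this assay, at which 2 of the 4 values shown sit.

The step between these two compounds cannot be read, so a second aromatic ring at this place adds only floors: an at least 1.9-fold higher number from compound 2 to compound 4 (0.29 log units; that floor lies within the scatter) and an at least 1.3-fold higher number from compound 1 to compound 4 (0.12 log units; that floor lies within the scatter). Neither floor separates compound 4 from the two compounds that have numbers.

No step beyond the scatter has yet appeared at this place. On these data alone, whether a longer alkyl chain or an aminoethyl group would give one stays open.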